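The source may hold more compounds than are shown below. What is called first, only, known or untested is meant among the compounds shown, and "the series" means these compounds.

Measured so far in an ADME assay on Huh-7 cells (Homo sapiens) for cytotoxicity, read by MTT assay, with a stated time of 96 h; a lower number here means that less compound is tolerated, a higher number that more compound is tolerated:
compound 1 `COc1cc(NCc2scnc2C)ccc1-c1cnco1`: 58500 nM
compound 2 `COc1cc(/N=C/C=C/c2ccccc2)ccc1-c1cnco1`: > 100000 nM
compound 3 `COc1cc(/N=C/c2cccs2)ccc1-c1cnco1`: > 100000 nM

Within the data shown here, compound 1 gives the only actual number among the three in this assay. The value of compound 2 is a limit of this assay, not a number. The value of compound 3 is likewise a limit. Two of the three results sit at the limit of > 100000 nM in this assay, at which 2 of the 3 values shown sit, so compound 1 stands alone as the one with a measurable concentration. Compound 4 `COc1cc(NCc2ccc(Br)s2)ccc1-c1cnco1` differs from compound 1 by 5-bromothiophen-2-yl in place of 4-methyl-1,3-thiazol-5-yl on a saturated chain carbon bound to a nitrogen on an aromatic ring. Among the measured compounds shown here, no step between measured compounds covers this change. The expectation is a step from compound 1 to compound 4 of about a 1.5-fold lower number from compound 1 to compound 4 (0.17 log units; within the scatter), within the usual scatter, toward slightly less tolerated. Compound 4 is therefore estimated at 40000 nM, in the range 15000 nM to 100000 nM.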

Compound 4, half-maximal cytotoxic concentration: 39400 nM
The estimate for compound 4 lay 1.0-fold (0.01 log units) above the measured number; the measured number falls inside the stated range.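

Read in this assay, this position now has a step that can be read, a 1.5-fold lower number from compound 1 to compound 4 (0.17 log units; within the scatter), so compound 1 and compound 4 cannot be told apart here. On this saturated chain carbon, a five-membered aromatic ring with 1 hetero atom and a bromine therefore gives a measurable value, just as the ring with 2 hetero atoms and a methyl does. Nothing shown gives a cause for this small step.

The ring and its substituent change together, so their shares stay unseparated. From the compounds shown here alone, whether a carboxylic acid or a dimethylamino group at this place would give a similar value stays open.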